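This account rests on a few compounds, and the source may have more. Where it says the series, first, only, none or still open, it means among the compounds named here.

Working notes on the series. In a functional assay on LNCaP cells (Homo sapiens) for antiproliferative activity, read by propidium iodide staining, with a stated time of 96 h (a higher number here means a weaker inhibitor, a lower number a stronger inhibitor), compound 1 `CC(O)(CSc1ccc(S(F)(F)(F)(F)F)cc1)C(=O)Nc1ccc([N+](=O)[O-])c(C(F)(F)F)c1` gives 8700 nM and compound 2 `CC(O)(COc1cccc(S(F)(F)(F)(F)F)c1)C(=O)Nc1ccc(C#N)cc1C(F)(F)F` gives 9900 nM as its value. Among the measured compounds shown here, these two numbers lie within the scatter of each other, so compound 2 stands level with the only other measured compound, and no measured step in one place is available. Compound 3 `CC(O)(COc1cccc(S(F)(F)(F)(F)F)c1)C(=O)Nc1ccc([N+](=O)[O-])cc1C(F)(F)F` follows from compound 2 through nitro in place of cyano on an aromatic carbon with nitro in place of cyano on an aromatic carbon, meta to a trifluoromethyl group and para to a large group. No shift beyond the scatter is expected in this assay for this change. Nitro is already carried by compound 1, which at 8700 nM lies within the scatter of compound 2, though the two differ elsewhere as well. The expected move is a 1.1-fold lower number from compound 2 to compound 3 (0.04 log units; within the scatter) and stays small. Compound 3 is estimated at 9000 nM with 4000 nM to 20000 nM as the expected range.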

Compound 3, half-maximal inhibitory concentration: 12100 nM
Compound 3: the middle estimate sits 1.3-fold (0.13 log units) below what was measured; the range from low to high includes it.
By their numbers in this assay, from the lowest: compounds 1, 2 and 3 (each within the scatter of the next).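

In this assay, among the compounds shown here, the first measured step at this position is a 1.2-fold higher number from compound 2 to compound 3 (0.09 log units; within the scatter), with nitro in place of cyano on an aromatic carbon meta to a trifluoromethyl group and para to a large group. For the compounds shown here, this step lies within the scatter, so the assay does not separate the two groups on this core, which the earlier compounds, differing in more than one place, could not show. No supporting measurement bears on this result.

Going by these compounds, whether an amine or a carboxylic acid on this aromatic carbon would move the number beyond the scatter remains open. A single pair also leaves open whether nitro and cyano would stay level if the large group para to this carbon were changed.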